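Aromatic methyl step, read across from compound 1 to compound 2

A few compounds are considered here, and "the series" means these few. Any claim that something is new, unique, unknown or untested is made for them only; others in the source may bear on it.

Measured so far in a functional assay on HL-60 cells (Homo sapiens) for cytotoxicity, read by WST assay, with a stated time of 48 h; on this read-out higher numbers stand for an effect only at larger amounts of compound and lower numbers for an effect already at smaller amounts:
compound 1 `O=C1OC[C@H](Cc2ccccc2)[C@H]1Cc1ccccc1`: 77000 nM
compound 2 `Cc1ccccc1C[C@H]1C(=O)OC[C@@H]1Cc1ccccc1`: 57000 nM
compound 3 `Cc1ccc(C[C@H]2COC[C@@H]2Cc2ccc(Cl)c(Cl)c2)cc1`: 21000 nM

Compound 3 gives the lowest number of the three; compound 2 stands nearest to it and compound 1 furthest, both beyond the scatter. Compound 1 and compound 2 differ by methyl in place of hydrogen on an aromatic carbon, and the step of a 1.4-fold lower number from compound 1 to compound 2 (0.13 log units; within the scatter). The cores of compound 1 and compound 3 differ as well, but that difference is not broken down here.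

Compound 4 `Cc1ccc(C[C@H]2COC[C@@H]2Cc2ccc(Cl)c(Cl)c2)cc1C` is not yet measured in this assay. It differs from compound 3 by methyl in place of hydrogen on an aromatic carbon. This is the same kind of change as from compound 1 to compound 2, not the same change: in compound 2 the entering methyl sits ortho to a large group, whereas in compound 4 it sits ortho to a methyl group and meta to a large group. For the measured compounds named here, only one measured example of this kind of step exists, and it stayed within the scatter.

The expectation for compound 4 rests on the step of a 1.4-fold lower number from compound 1 to compound 2 (0.13 log units; within the scatter) read across onto compound 3, giving an expected step of a 1.3-fold lower number from compound 3 to compound 4 (0.12 log units; within the scatter). Compound 4 is therefore estimated at 16000 nM in this assay, with an expected range from 7000 nM to 40000 nM. The measured value for compound 4 follows.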

Compound 4, half-maximal effective concentration: 36000 nM
Beside the measured number, compound 4's estimate is 2.3-fold (0.35 log units) below it; low and high end bracket the measured number.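

In this assay, methyl in place of hydrogen on an aromatic carbon gives a 1.7-fold higher number from compound 3 to compound 4 (0.23 log units; within the scatter), a step that lies within the scatter, so the change moves the number by no measurable amount on this core. Set beside the earlier step on the core of compound 1, the new step cannot be told apart from it: the same change on two cores in this assay, a 1.4-fold lower number (0.13 log units; within the scatter) from compound 1 to compound 2 and a 1.7-fold higher number (0.23 log units; within the scatter) from compound 3 to compound 4, 2.3-fold (0.36 log units) apart, within the scatter of two such steps. This shows that the change left the read-out within the scatter on both cores; it does not show that the change carries a fixed size or direction from one core to another, and two steps, with the methyl in a different setting in compound 4, ortho to a methyl group and meta to a large group, are too few to show that the setting of the methyl has no bearing on the result.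

The compounds shown leave open whether a larger or differently built group on the same aromatic carbon, such as an amine, a carboxylic acid or a longer chain, would give a step beyond the scatter on either core. They also leave open whether methyl at another place on the ring would stay within the scatter.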